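The source may report more compounds than this note shows. Statements on the series, on what has been measured and on what is new or still open speak of the compounds shown alone.

Compound 1, `COc1ccc(C2N=C(SCc3ccccc3)NC(C)=C2C(=O)Nc2ccc(Br)cc2)cc1`, and compound 2, `COc1ccc(C2N=C(SCc3ccccc3Cl)NC(C)=C2C(=O)Nc2ccc(Br)cc2)cc1`, share one core, and the second differs from the first by chloro in place of hydrogen on an aromatic carbon. In a functional assay on the whole organism (artery, strain albino) with Rattus norvegicus as the target, with a stated time of 240 min, at a dose of 10 mg/kg by the oral route (on this read-out higher numbers stand for more inhibition at the one dose given (going by the name of the read-out) and lower numbers for less inhibition), compound 1 gives 13.3%, while compound 2 gives 15.4%; the step of a number 2.1 percentage points higher from compound 1 to compound 2 (within the scatter) is within the scatter, so the two numbers cannot be told apart. Compound 3, `CC1=C(C(=O)Nc2ccc([N+](=O)[O-])cc2)C(c2ccc(Br)cc2)N=C(SCc2ccccc2)N1`, rests on a different core; how that core differs from the core of compound 1 is not broken down here. In this assay compound 3 gives 27.7%, the highest of the three numbers, and its gaps to compound 2 and to compound 1 both lie beyond the scatter.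

Compound 4, `CC1=C(C(=O)Nc2ccc([N+](=O)[O-])cc2)C(c2ccc(Br)cc2)N=C(SCc2ccccc2Cl)N1`, has not yet been measured. It differs from compound 3 by chloro in place of hydrogen on an aromatic carbon, and this is the same change that leads from compound 1 to compound 2, at the same place, ortho to a large group on a six-membered aromatic ring of carbon only. Because the earlier step of a number 2.1 percentage points higher from compound 1 to compound 2 (within the scatter) stayed within the scatter, the step from compound 3 to compound 4 is expected to be small as well, roughly a number 2.3 percentage points higher from compound 3 to compound 4 (within the scatter), with the new core of compound 3 as the starting point. On that basis compound 4 is estimated to give about 30% in this assay, most likely somewhere between 18% and 42%.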

Compound 4, a percentage reported as inhibition, in the whole organism at one dose (the size of the read-out at that dose, not a potency): 15.4%
Estimate against measurement, compound 4: 14.6 percentage points above; the measured number lies below the stated range.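

In this assay, the change from benzyl to 2-chlorobenzyl gives a number 12.3 percentage points lower from compound 3 to compound 4 (beyond the scatter), and set beside the same change on the core of compound 1, this shows that the two cores do not respond alike: the same change on two cores in this assay, a number 2.1 percentage points higher (within the scatter) from compound 1 to compound 2 and a number 12.3 percentage points lower (beyond the scatter) from compound 3 to compound 4, 14.4 percentage points apart, beyond the scatter of two such steps. A step that stays within the scatter on one core therefore gave no safe guide to the same step on the other, and in this series the change could not simply be carried from one core to the next. For the compounds shown here, with only one pair on each core, however, this does not show which part of the difference between the cores goes with the different outcome, nor how the change would behave on any further core, and it rests on a reading at a single dose rather than on a potency.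

The compounds shown carry only hydrogen or chloro at this place on the benzyl group, so it remains open how a fluoro, a methyl or a methoxy group there would read on either core. Also open, as far as these compounds go, is what would follow if the benzylsulfanyl group gave way to an amine or a longer alkyl chain.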